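Replacing a Naphthalene Amide in a Thiophene Antiproliferative Series

This account rests on a few compounds, and the source may have more. Where it says the series, first, only, none or still open, it means among the compounds named here.

Compound 1 `COC(=O)c1scc(-c2ccc(NC(=O)c3ccc4ccccc4c3)cc2)c1OC` is the reference point here. In a functional assay on MCF7 cells (Homo sapiens) for antiproliferative activity, read by MTT assay, with a stated time of 24 h (on this read-out lower numbers stand for stronger inhibition and higher numbers for weaker inhibition), compound 1 gives 90 nM, the lowest of the two numbers measured, so it stands as the stronger of the two. Going by the values given here, its only measured partner is compound 2 `COC(=O)c1scc(-c2ccc(NC(=O)c3ccccn3)cc2)c1OC`, which in this assay gives 19200 nM; the change a 210-fold higher number from compound 1 to compound 2 (2.33 log units; beyond the scatter) shows how much the aromatic group on the amide carbonyl can matter.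

Compound 3 `COC(=O)c1scc(-c2ccc(NC(=O)c3cc(I)ccc3F)cc2)c1OC` differs from compound 1 at the same position: 2-fluoro-5-iodophenyl in place of naphthalen-2-yl on a carbonyl carbon. Among the compounds with values here, no measured step covers a halogenated single ring, but the only comparable step, from the naphthalene to a pyridine, was large and in the weakening direction. A smaller loss than that is expected, since a carbon-only ring is kept, but some loss seems likely, so for compound 3 a step of a 17-fold higher number from compound 1 to compound 3 (1.22 log units; beyond the scatter) is expected. Compound 3 is therefore estimated at 1500 nM, within a range from 250 nM to 9000 nM.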

Compound 3, half-maximal inhibitory concentration: 22500 nM
The estimate for compound 3 lay 15-fold (1.18 log units) below the measured number; the measured number lies above the stated range.
By their numbers in this assay, from the lowest: compound 1; then compounds 2 and 3 (each within the scatter of the next).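

In this assay, the step of a 250-fold higher number from compound 1 to compound 3 (2.40 log units; beyond the scatter) shows that a large rise in the number on leaving naphthalen-2-yl is not confined to the pyridine, since it also appears with 2-fluoro-5-iodophenyl, a ring of carbon only. The two single-ring groups cannot be told apart in this assay, as the step of a 1.2-fold higher number from compound 2 to compound 3 (0.07 log units; within the scatter) lies within the scatter, so on these compounds the ring nitrogen of compound 2 makes no visible difference. Nothing measured here explains why compound 1 stands apart from both.

Still open, going by these compounds, is whether another two-ring group, such as quinolin-2-yl, would keep a number close to that of compound 1. It is also unknown how a plain phenyl, or a phenyl carrying only fluorine or only iodine, would compare with compound 3.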